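The source may hold more compounds than are shown below. What is called first, only, known or untested is meant among the compounds shown, and "the series" means these compounds.

In an ADME assay on HepG2 cells (Homo sapiens) for cytotoxicity, read by luminescence, CellTiter-Glo and ATP content, with a stated time of 72 h (on this read-out higher numbers stand for an effect only at larger amounts of compound and lower numbers for an effect already at smaller amounts), compound 1 (`CCC(CC)c1ccc2c(NCCCNCc3cc(F)ccc3OC)ccnc2c1`) gives 7860 nM and compound 2 (`CCC(CC)c1ccc2c(NCCCNCc3ccco3)ccnc2c1`) gives 6760 nM, the two lying within the scatter of each other. Compound 3 (`FC(F)(F)c1cc(-c2ccc3c(NCCCNCc4ccco4)ccnc3c2)cc(C(F)(F)F)c1`) gives 2410 nM, a lower number than that of compound 1 by more than the scatter.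

Compound 4 (`COc1ccc(F)cc1CNCCCNc1ccnc2cc(CCC(C)C)ccc12`) has the same atoms as compound 1, joined differently: isopentyl in place of pentan-3-yl on an aromatic carbon. Isopentyl replaces pentan-3-yl on an aromatic carbon, and no measured pair isolates this exchange.

Among the measured compounds shown here, the one step available, a 1.2-fold lower number from compound 1 to compound 2 (0.07 log units; within the scatter), concerns a different group, so it bears on the present change only indirectly. For the measured compounds named here, it stayed within the scatter, which gives no precedent for a large move on a single exchange in this small set. No shift beyond the scatter is therefore expected in this assay, and no firm direction can be assigned. The expected change is a 1.1-fold lower number from compound 1 to compound 4 (0.05 log units; within the scatter). For compound 4 the estimated value is 7000 nM, with an expected range of 3500 nM to 14000 nM.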

Compound 4, half-maximal effective concentration: 890 nM
For compound 4 the middle estimate is 7.9-fold (0.90 log units) above the measured one; measured number below the stated range.
By their numbers in this assay, from the lowest: compound 4; then compound 3; then compounds 2 and 1 (each within the scatter of the next).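

In this assay, isopentyl in place of pentan-3-yl on the aromatic carbon gives an 8.8-fold lower number from compound 1 to compound 4 (0.95 log units; beyond the scatter), so this position responds to how the same five carbons are joined, with no change in heavy atoms, rings, hydrogen-bond donors or acceptors, or net charge. The earlier single-place step, furan-2-yl in place of 5-fluoro-2-methoxyphenyl, gave a 1.2-fold lower number from compound 1 to compound 2 (0.07 log units; within the scatter) and showed no such sensitivity, though it concerned a different group. No measured evidence here bears on the origin of this shift.

The compounds shown leave open whether isopentyl gives a similar step when furan-2-yl replaces 5-fluoro-2-methoxyphenyl. They also leave open how a longer chain, such as n-hexyl, or a cyclohexyl ring on this aromatic carbon would read in this assay.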